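Replacing the Trimethylimidazolyl Group with a Triazolyl Ester

A few compounds are considered here, and "the series" means these few. Any claim that something is new, unique, unknown or untested is made for them only; others in the source may bear on it.

Compound 1, `CCO/C(O)=C1\C(COCCn2cc(N)n(C)c2=O)=NC(C)=C(C(=O)OC)C1c1ccccc1Cl`, gives 25.1 nM in a functional assay (aorta) with Rattus norvegicus as the target; on this read-out higher numbers stand for weaker inhibition and lower numbers for stronger inhibition.
Compound 2, `CCO/C(O)=C1\C(COCCn2c(C)nc(C)c2C)=NC(C)=C(C(=O)OC)C1c1ccccc1Cl`, gives 5.01 nM in this assay.
Compound 3, `CCO/C(O)=C1\C(COCCn2cc(N)nc2O)=NC(C)=C(C(=O)OC)C1c1ccccc1Cl`, gives 31.6 nM in this assay.

Three compounds share one core and differ only in the five-membered aromatic ring hung from the side chain. Compound 2 stands lowest of the three numbers, which here means the strongest inhibition; the others are separated from it by a 5.0-fold lower number from compound 1 to compound 2 (0.70 log units; beyond the scatter) and a 6.3-fold higher number from compound 2 to compound 3 (0.80 log units; beyond the scatter), both beyond the scatter, while compounds 1 and 3 lie within the scatter of each other.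

Compound 4, `CCOC(=O)c1cn(CCOCC2=NC(C)=C(C(=O)OC)C(c3ccccc3Cl)/C2=C(\O)OCC)nn1`, has not been measured. It differs from compound 2 by 4-(ethoxycarbonyl)-1H-1,2,3-triazol-1-yl in place of 2,4,5-trimethyl-1H-imidazol-1-yl on a saturated chain carbon, two bonds along the chain from an oxygen on a saturated carbon. Both measured steps away from the trimethylimidazolyl ring led to higher numbers, so the new ring is expected to do the same, a modest rise rather than a large one. Compound 4 is therefore estimated to give 20 nM in this assay, within 6 nM to 63 nM, an expected step of a 4.0-fold higher number from compound 2 to compound 4 (0.60 log units; beyond the scatter).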

Compound 4, half-maximal inhibitory concentration: 50.1 nM
The estimate for compound 4 lay 2.5-fold (0.40 log units) below the measured number; the range from low to high includes it.
By their numbers in this assay, from the lowest: compound 2; then compounds 1, 3 and 4 (each within the scatter of the next).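

In this assay, moving from the trimethylimidazolyl ring to the triazolyl ester gives a 10-fold higher number from compound 2 to compound 4 (1.00 log units; beyond the scatter), so all three other rings now stand beyond the scatter of compound 2, which remains the strongest inhibitor of the four. The new ring also falls level with the two amino-bearing imidazole-type rings, with a 1.6-fold higher number from compound 3 to compound 4 (0.20 log units; within the scatter) and a 2.0-fold higher number from compound 1 to compound 4 (0.30 log units; within the scatter), so a different ring with an added ester does not separate it from them at this position. No measurement shown here accounts for this result.

The step to compound 4 changes the ring and adds the ester together, so their separate contributions remain unresolved. A plain 1H-1,2,3-triazol-1-yl ring, a carboxylic acid in place of the ethyl ester, or an imidazole without its three methyl groups would help to pull these effects apart.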